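Swapping One Aryl Group for Another on the Amine

A few compounds are considered here, and "the series" means these few. Any claim that something is new, unique, unknown or untested is made for them only; others in the source may bear on it.

Compound 1 `Cc1ccc(NC2=CC(=O)c3c(nc4n3[C@H]3OC[C@@H](O)[C@H]3OC4)C2=O)cc1C` carries a 3,4-dimethylphenyl group on an amine nitrogen. For the measured compounds named here, in a functional assay on HeLa cells (Homo sapiens) for inhibition, read by sulforhodamine B assay (a lower number here means a stronger inhibitor, a higher number a weaker inhibitor), compound 1 gives 4320 nM, the only actual number among the three measured compounds. Compound 2 `O=C1C=C(NC2CCCC2)C(=O)c2c1nc1n2[C@H]2OC[C@@H](O)[C@H]2OC1` carries a cyclopentyl group on that nitrogen; in this assay compound 2 stops at the limit of > 16000 nM. Compound 3 `O=C1C=C(NC2CCCCC2)C(=O)c2c1nc1n2[C@H]2OC[C@@H](O)[C@H]2OC1` carries a cyclohexyl group; in this assay compound 3 also stops at the limit of > 16000 nM. Going by the values given here, the one measured step, a step that the two limits leave unreadable from compound 2 to compound 3, joins two compounds that both sit at the limit of > 16000 nM in this assay, at which 2 of the 3 values shown sit.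

Compound 4 `O=C1C(Nc2ccc(C(F)(F)F)cc2)=CC(=O)c2c1nc1n2[C@H]2OC[C@@H](O)[C@H]2OC1` differs from compound 1 by 4-(trifluoromethyl)phenyl in place of 3,4-dimethylphenyl on an amine nitrogen. Among the compounds with values here, no measured step exchanges one aryl group for another, so no shift beyond the scatter is expected for a 1.2-fold higher number from compound 1 to compound 4 (0.06 log units; within the scatter). Compound 4 is therefore estimated at 5000 nM, between 1500 nM and 16000 nM.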

Compound 4, half-maximal inhibitory concentration: 8920 nM
Beside the measured number, compound 4's estimate is 1.8-fold (0.25 log units) below it; the measured number falls inside the stated range.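

The exchange of one aryl group for another on this amine nitrogen is not neutral: in this assay, it gives a 2.1-fold higher number from compound 1 to compound 4 (0.31 log units; beyond the scatter), a modest step. For the compounds shown here, this is the first step that can be read as a size, and compound 4 is the weaker inhibitor of the pair. Nothing shown accounts for the shift.

The comparison cannot separate the gain of trifluoromethyl from the loss of the two methyl groups. A plain phenyl group or a 4-methoxyphenyl group on this nitrogen remains an open case.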